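Notes on the aryl group at the saturated ring carbon

The source may hold more compounds than are shown below. What is called first, only, known or untested is meant among the compounds shown, and "the series" means these compounds.

Measured so far:
compound 1 `COc1cc(/C=C/C(=O)C2=C(/C=C/c3ccc(O)c(OC)c3)NC(=O)NC2c2ccc(C)cc2)ccc1O` — 46%
compound 2 `COc1cc(/C=C/C(=O)C2=C(/C=C/c3ccc(O)c(OC)c3)NC(=O)NC2c2ccc(O)cc2)ccc1O` — 90.3%

Both numbers come from a functional assay, with a stated time of 20 min, tested at 50 uM; on this read-out higher numbers stand for a stronger effect at the one concentration tested and lower numbers for a weaker effect. Among the compounds with values here, compound 1 stands lowest of the two; its nearest neighbour is compound 2, and the one step that joins them, a number 44.3 percentage points higher from compound 1 to compound 2 (beyond the scatter), is a large rise beyond the scatter.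

Compound 3 `COc1cc(/C=C/C(=O)C2=C(/C=C/c3ccc(O)c(OC)c3)NC(=O)NC2c2c(Cl)cccc2Cl)ccc1O` is not yet measured. It departs from compound 1 at the same place as compound 2 does, but in another way: 2,6-dichlorophenyl in place of 4-methylphenyl on a saturated ring carbon.

Within the data shown here, the only measured step that bears on this change is a number 44.3 percentage points higher from compound 1 to compound 2 (beyond the scatter). That step brings in a hydrogen-bond donor, whereas the group entering in compound 3 carries none, as the group leaving carried none. The data therefore give no measured change of this kind to lean on, and the large rise seen for compound 2 cannot simply be carried over. Without a step that matches, the expectation for compound 3 is a change from compound 1 of no clear size, a number 4 percentage points higher from compound 1 to compound 3 (within the scatter), in either direction within a wide band. Compound 3 is thus estimated at 50%, between 25% and 78%, in this assay.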

Compound 3, a percentage reported as activity, at one concentration (the size of the read-out at that concentration, not a potency): 43.2%
Compound 3: middle estimate off by 6.8 percentage points, on the high side; measured number inside the range.
By their numbers in this assay, from the lowest: compounds 3 and 1 (each within the scatter of the next); then compound 2.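

In this assay, replacing 4-methylphenyl with 2,6-dichlorophenyl on the saturated ring carbon leaves the read-out within the scatter, a number 2.8 percentage points lower from compound 1 to compound 3 (within the scatter), even though the entering group differs in both its substituents and where they sit on the phenyl ring. Set against 4-hydroxyphenyl, the same group gives a number 47.1 percentage points lower from compound 2 to compound 3 (beyond the scatter), so among these three compounds the aryl groups without a hydrogen-bond donor, in compound 1 and compound 3, read alike, and only compound 2 stands apart, which makes the link to the hydroxy group a pattern resting on that one compound. No measurement on hand explains either step.

The compounds shown leave open whether the high number of compound 2 needs the free hydroxy group itself, or whether a methoxy group or an amine on the phenyl ring at that place would hold it. They also leave open whether a single chlorine on the phenyl ring would read like the pair in compound 3, since that group changes the substituents and their placing at once.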